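The compounds below may be only part of what the source reports. "The series", "measured", "known", "first", "only" and "open" are said of these compounds alone.

The measured compounds and their results in an assay on nucleic acid for inhibition of Nucleic Acid, read by fluorescence, tested at 100 uM; a higher number here means more inhibition at the concentration tested (going by the name of the read-out), a lower number less inhibition:

Compound 1, `CN(Cc1cn(CC(O)COC(=O)C2CCCCC2)nn1)CC1CCCCC1`, gives 18%.
Compound 2, `CCCCN(CCCC)Cc1cn(C2CCCCC2OC(=O)COc2ccccc2)nn1`, gives 26%.
Compound 3, `CCOC(=O)C1CCCN(Cc2cn(CC(O)COC(=O)NCc3ccccc3)nn2)C1`, gives 47%.

Compound 3 stands highest of the three, and its distance to compound 2 and to compound 1 lies beyond the usual scatter in both cases.

Compound 4, `CCOC(=O)C1CCCN(Cc2cn(CC(O)COCc3ccccc3)nn2)C1`, shares the core of compound 3 and differs only as follows: benzyl in place of benzylcarbamoyl on an oxygen on a saturated carbon. For the measured compounds named here, no measured pair differs in this way, so the size of such a change is not known from these data. The expected step of a number 9 percentage points lower from compound 3 to compound 4 (within the scatter) is a modest decrease, possibly not beyond the scatter. Compound 4 is therefore estimated at 38%, with a range from 20% to 55%.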

Compound 4, a percentage reported as inhibition, at one concentration (the size of the read-out at that concentration, not a potency): 26%
Compound 4: middle estimate off by 12 percentage points, on the high side; the range from low to high includes it.
By their numbers in this assay, from the lowest: compounds 1, 2 and 4 (each within the scatter of the next); then compound 3.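

Replacing benzylcarbamoyl with benzyl on an oxygen on a saturated carbon gives a number 21 percentage points lower from compound 3 to compound 4 (beyond the scatter) in this assay. For the compounds shown here, this is the first pair differing in one place, and it shows that the result responds to a change at this position. Both groups carry a six-membered aromatic ring of carbon only, so that ring alone does not keep the higher number; nothing measured here explains the step. On these data alone, whether the carbonyl or the nitrogen of the departing group matters remains open, and a benzoyl group on the same oxygen would help separate them. A methylcarbamoyl group there would test whether the aromatic ring is needed at all.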